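Moving the Pyridine Nitrogen in Compound 3

The compounds below may be only part of what the source reports. "The series", "measured", "known", "first", "only" and "open" are said of these compounds alone.

Values in an ADME assay on LLC-PK1 cells (Sus scrofa) for permeability; on this read-out higher numbers stand for higher permeability and lower numbers for lower permeability:
- compound 1 `Cn1nc(C(=O)Nc2ccc(-c3ccccc3)c(C(F)(F)F)c2)c(=O)c2ccccc21`: 2.3 10^-6 cm/s
- compound 2 `Cn1cc(C(=O)Nc2cnc(-c3ccccc3)c(C(F)(F)F)c2)c(=O)c2ccccc21`: 11 10^-6 cm/s
- compound 3 `Cn1cc(C(=O)Nc2ccc(-c3cccnc3)c(C(F)(F)F)c2)c(=O)c2ccccc21`: 18 10^-6 cm/s

Compound 3 has the highest number of the three, although it lies within the usual scatter of compound 2 and only clearly beyond that of compound 1. Compound 4 `Cn1cc(C(=O)Nc2ccc(-c3ccccn3)c(C(F)(F)F)c2)c(=O)c2ccccc21` has the same atoms as compound 3, joined differently, with pyridin-2-yl in place of pyridin-3-yl on an aromatic carbon. Going by the values given here, no measured pair shows this change, so the best starting point is compound 3 at 18 10^-6 cm/s. The expected 1.1-fold higher number from compound 3 to compound 4 (0.05 log units; within the scatter) is no change beyond the scatter in this assay. For compound 4 the estimated value is 20 10^-6 cm/s, with an expected range of 9 10^-6 cm/s to 40 10^-6 cm/s.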

Compound 4, apparent permeability in the LLC-PK1 assay: 11 10^-6 cm/s
The estimate for compound 4 lay 1.8-fold (0.26 log units) above the measured number; the range from low to high includes it.
By their numbers in the LLC-PK1 assay, from the lowest: compound 1; then compounds 2, 4 and 3 (each within the scatter of the next).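

Going by these compounds alone, this pair gives the first direct comparison of pyridin-2-yl with pyridin-3-yl at this position, ortho to the trifluoromethyl group: in the LLC-PK1 assay the swap gives a 1.6-fold lower number from compound 3 to compound 4 (0.21 log units; within the scatter), and in a physicochemical assay for solubility, at pH 7.4 (on this read-out lower numbers stand for lower solubility and higher numbers for higher solubility), where compound 3 gives 23 ug/mL and compound 4 gives 12 ug/mL, it gives a 1.9-fold lower number from compound 3 to compound 4 (0.28 log units; within the scatter). Moving the ring nitrogen here therefore produces no change beyond the scatter on either read-out. No evidence is available on what lies behind these two small steps.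

Still open, as far as these compounds go, is how a pyridin-4-yl group would compare at this position. Also open, from the compounds shown here alone, is what an amine or a carboxylic acid on this ring would do to either read-out.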